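One Ring Swap on the Triple-Bonded Arm

This account rests on a few compounds, and the source may have more. Where it says the series, first, only, none or still open, it means among the compounds named here.

Compound 1 `CCc1ccc2ncn(-c3ccnc(N)n3)c2c1`: 79400 nM
Compound 2 `C=CC(=O)NCCCc1ccc2ncn(-c3ccnc(N)n3)c2c1`: 501000 nM
Compound 3 `C=Cc1ccnc(C#Cc2ccc3ncn(-c4ccnc(N)n4)c3c2)c1`: 1580 nM

All three numbers come from an assay on Sf9 cells for inhibition of mitogen-activated protein kinase kinase kinase 14 variant S549D (Homo sapiens), with a stated time of 30 min, in the presence of a further agent that is not named here; on this read-out lower numbers stand for stronger inhibition and higher numbers for weaker inhibition. Compound 3 stands lowest of the three, with compound 1 nearest to it and compound 2 furthest away. Among the measured compounds shown here, the only measured step, a 6.3-fold higher number from compound 1 to compound 2 (0.80 log units; beyond the scatter), concerns a saturated chain on the shared core and says nothing about the arm on the triple bond. Compound 4 `C#Cc1ncc(C#Cc2ccc3ncn(-c4ccnc(N)n4)c3c2)cn1` differs from compound 3 only there: a group of 8 heavy atoms (6 carbon, 2 nitrogen; one six-membered aromatic ring with 2 hetero atoms) in place of a group of 8 heavy atoms (7 carbon, 1 nitrogen; one six-membered aromatic ring with 1 hetero atom), on a triple-bonded carbon. For the measured compounds named here, no measured pair touches this arm, so the expectation for compound 4 rests on compound 3 alone, which gives 1580 nM: a number near that one is expected, with a step of a 1.3-fold higher number from compound 3 to compound 4 (0.10 log units; within the scatter) and a wide spread allowed. Compound 4 is therefore estimated at 2000 nM, between 500 nM and 8000 nM.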

Compound 4, half-maximal inhibitory concentration: 79400 nM
The estimate for compound 4 lay 40-fold (1.60 log units) below the measured number, and the stated range ends below it.
By their numbers in this assay, from the lowest: compound 3; then compounds 1 and 4 (each within the scatter of the next); then compound 2.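

This position on the triple-bonded carbon is sensitive to what it carries: exchanging one ring group for another gives a 50-fold higher number from compound 3 to compound 4 (1.70 log units; beyond the scatter). Both groups have 8 heavy atoms and one six-membered aromatic ring, so a swap that leaves those counts unchanged can still move the number a long way. No measurement here explains the step.

The compounds shown leave open whether the second ring nitrogen or the triple bond replacing the double bond matters more. Going by these compounds, how a ring carrying an amine would fare at this position also remains open.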